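This account rests on a few compounds, and the source may have more. Where it says the series, first, only, none or still open, it means among the compounds named here.

Among the measured compounds shown here, compound 1 `CC1=C(C(=O)OCC(C)O[N+](=O)[O-])C(c2cccc3nonc23)C([N+](=O)[O-])=C(C)C1` stands lowest of the two numbers measured so far in a functional assay (ileum) for antagonist activity, with Cavia porcellus as the target; on this read-out lower numbers stand for stronger inhibition and higher numbers for weaker inhibition: compound 1 gives 1700 nM. The other measured compound, compound 2 `CC1=C(C(=O)O[C@H](C)CO[N+](=O)[O-])[C@H](c2cccc3nonc23)C([N+](=O)[O-])=C(C)C1`, gives 36500 nM in this assay, a clearly higher number. Compound 3 `CC1=C(C(=O)OCCCO[N+](=O)[O-])C(c2cccc3nonc23)C([N+](=O)[O-])=C(C)C1` is not yet measured; it differs from compound 1 in one place: 2-(nitrooxy)ethyl in place of 1-(nitrooxy)ethyl on a saturated chain carbon bound to an oxygen next to a carbonyl group. For the measured compounds named here, no measured pair shows a change of this kind, so for compound 3 the expected step of a 1.2-fold higher number from compound 1 to compound 3 (0.07 log units; within the scatter) is small, in no fixed direction, and probably within the usual scatter. Compound 3 is estimated at 2000 nM, in the range 700 nM to 6000 nM.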

Compound 3, half-maximal inhibitory concentration: 241 nM
Compound 3: middle estimate off by 8.3-fold (0.92 log units), on the high side; measured number outside the range, below it.
By their numbers in this assay, from the lowest: compound 3; then compound 1; then compound 2.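

In this assay, among the compounds shown here, the change to 2-(nitrooxy)ethyl in place of 1-(nitrooxy)ethyl gives a 7.1-fold lower number from compound 1 to compound 3 (0.85 log units; beyond the scatter) and so provides the first single-place step. This place on a saturated chain carbon bound to an oxygen next to a carbonyl group therefore responds to how the same atoms are joined, even though the counted atoms stay the same. Nothing available gives a reason for this step.

Open in this assay is how a longer chain carrying the nitrooxy group would compare with compound 3. From the compounds shown here alone, an amine or a carboxylic acid in place of the nitrooxy group is equally open.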